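Replacing the Tetrazole Tail with an Ester Chain

The compounds below may be only part of what the source reports. "The series", "measured", "known", "first", "only" and "open" are said of these compounds alone.

Of the compounds shown here, two built on the same core have been measured in an assay on isolated protein for binding affinity to cysteinyl leukotriene receptor 1 (Cavia porcellus); a lower number here means a stronger inhibitor, a higher number a weaker inhibitor. Compound 1, `c1cc(OCc2ccc3ccccc3n2)cc(-c2nn[nH]n2)c1`, gives 115 nM in this assay. Compound 2, `c1ccc2nc(COc3ccc(Cc4nnn[nH]4)cc3)ccc2c1`, gives 275 nM in this assay, the higher of the two numbers; the gap to compound 1 lies beyond the usual scatter, so compound 2 is the weaker binder of the pair.

Compound 3, `CCOC(=O)CCCOc1ccc(OCc2ccc3ccccc3n2)cc1`, is the next point, and it has not yet been measured. It differs from compound 2 in one place: 3-(ethoxycarbonyl)propoxy in place of (1H-tetrazol-5-yl)methyl on an aromatic carbon. For the measured compounds named here, no pair among the measured compounds shows a change of this kind, so there is no measured step to lean on, and the expectation rests on the two values alone.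

The author expects compound 3 to give a clearly higher number than compound 2 in this assay, a step from compound 2 to compound 3 estimated at a 9.1-fold higher number from compound 2 to compound 3 (0.96 log units; beyond the scatter), well beyond the scatter. The estimated value for compound 3 in this assay is 2500 nM, with a plausible range from 500 nM to 12000 nM; the uncertainty is wide because only compound 2 at 275 nM anchors the starting point.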

Compound 3, inhibition constant: 500 nM
The estimate for compound 3 lay 5.0-fold (0.70 log units) above the measured number; low and high end bracket the measured number.
By their numbers in this assay, from the lowest: compound 1; then compounds 2 and 3 (each within the scatter of the next).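

At this position, on an aromatic carbon para to a large group, the step is a 1.8-fold higher number from compound 2 to compound 3 (0.26 log units; within the scatter) in this assay, and it lies within the usual scatter, so compound 2 and compound 3 cannot be told apart in this read-out. The change removes a five-membered aromatic ring with 4 hetero atoms and the only hydrogen-bond donor of that group, and it puts an open 3-(ethoxycarbonyl)propoxy chain in their place, so for this pair neither that ring nor that donor is needed to keep the value within the scatter. Nothing measured here explains why the two compounds read alike.

The single swap changes the ring, the chain and the ester together, so the compounds shown cannot separate what each contributes. Still open, on these data alone, is whether the carboxylic acid of the same chain, a shorter or longer chain, or an amide in place of the ethyl ester would stay within the scatter of compound 3 or move clearly away from it.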